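Working notes: cytotoxicity outlook for compound 4

This account rests on a few compounds, and the source may have more. Where it says the series, first, only, none or still open, it means among the compounds named here.

Compound 1 `COC(=O)c1ccc(NCc2cncn2Cc2ccc(N)cc2)cc1-c1ccccc1` has been tested in a toxicity assay on NIH3T3 cells (Mus musculus) for cytotoxicity, read by resazurin assay; on this read-out higher numbers stand for an effect only at larger amounts of compound and lower numbers for an effect already at smaller amounts. In this assay compound 1 reaches only a limit of > 10000 nM. Compound 2 `N#Cc1ccc(NCc2cncn2Cc2ccc(-c3ccccc3)cc2)cc1-c1ccccc1` also gives only a limit, > 1000 nM, in this assay. Compound 3 `Cc1cccc(-c2cccc(NCc3cncn3Cc3ccccc3)c2)c1C` likewise stops at a limit of > 1000 nM in this assay. Within the data shown here, no number is therefore known for any of the three; the values sit at the limit of > 1000 nM in this assay, at which 2 of the 3 values shown sit, and at the limit of > 10000 nM in this assay, at which 1 of the 3 values shown sits, so no measured step between compounds exists and compound 1 stands at a limit rather than at a value.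

Compound 4 `COC(=O)c1ccc(NCc2cncn2Cc2ccccc2Br)cc1-c1ccccc1` is not yet measured in this assay. It differs from compound 1 by 2-bromophenyl in place of 4-aminophenyl on a saturated chain carbon bound to an aromatic nitrogen. Nothing within the series tells how such a change moves the read-out, so no direction beyond the scatter is assumed. Compound 4 is expected to give 10000 nM, within 3000 nM to 30000 nM, most probably again reported as a limit. The expected step is a number no higher from compound 1 to compound 4 (the limit leaves the size open), which amounts to none beyond the scatter.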

Compound 4, half-maximal effective concentration: 10000 nM
Estimate against measurement, compound 4: no gap at the digits printed, within the range that was stated.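

Among these compounds, compound 4 gives the first actual number in this assay, 10000 nM, so with 2-bromophenyl on a saturated chain carbon bound to an aromatic nitrogen the read-out is a value and not a limit. Exchanging 4-aminophenyl for 2-bromophenyl gives a number no higher from compound 1 to compound 4 (the limit leaves the size open), and the compounds differing in one place now form a first pair. The size of this step cannot be read because the value of compound 1 is a limit: the limit of > 10000 nM in this assay, at which 1 of the 4 values shown sits.

Open, from the compounds shown here alone, is how a 4-bromophenyl or a 2-chlorophenyl at the same place would read in this assay, which would separate the role of the bromine from that of its place on the ring. Also open, going by these compounds, is how a carboxylic acid in place of the methyl ester of compound 4 would read.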